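From 4-chlorophenyl to 4-methoxyphenyl

The source may hold more compounds than are shown below. What is called first, only, known or untested is meant among the compounds shown, and "the series" means these compounds.

Compound 1 `O=C(NNc1nc2ccccc2nc1Cc1ccccc1)c1ccccc1` gives 360000 nM in an assay for inhibition of Amine oxidase [flavin-containing] B (Bos taurus), read by fluorescence, with a stated time of 60 min; a higher number here means a weaker inhibitor, a lower number a stronger inhibitor. Compound 2 `O=C(NNc1nc2ccccc2nc1Cc1ccccc1)c1ccc(Cl)cc1` gives 730000 nM in this assay, the higher of the two numbers, and the step of a 2.0-fold higher number from compound 1 to compound 2 (0.31 log units; beyond the scatter) went with chloro in place of hydrogen on an aromatic carbon. Compound 3 `COc1ccc(C(=O)NNc2nc3ccccc3nc2Cc2ccccc2)cc1` differs from compound 2 by methoxy in place of chloro on an aromatic carbon, para to a large group. Within the data shown here, no measured step tests methoxy itself; the only comparable step, the chloro one, was modest. Compound 3 is therefore expected at a 1.5-fold lower number from compound 2 to compound 3 (0.16 log units; within the scatter), close to both measured numbers. The estimate for compound 3 is 500000 nM, between 200000 nM and 1300000 nM.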

Compound 3, half-maximal inhibitory concentration: 920000 nM
Compound 3: the middle estimate sits 1.8-fold (0.26 log units) below what was measured; the range from low to high includes it.
By their numbers in this assay, from the lowest: compound 1; then compounds 2 and 3 (each within the scatter of the next).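

With a 1.3-fold higher number from compound 2 to compound 3 (0.10 log units; within the scatter) in this assay, methoxy cannot be told apart from chloro at this position. Methoxy, like chloro, goes with a weaker inhibitor than hydrogen, with a 2.6-fold higher number from compound 1 to compound 3 (0.41 log units; beyond the scatter) for this change, so the two groups tested here both land on the weaker side of compound 1. No supporting measurement offers an explanation for this.

Going by these compounds, whether an amine or a carboxylic acid at this position would give a stronger inhibitor than compound 1 stays open. So does whether changes elsewhere on the shared core would matter more.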